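The compounds below may be only part of what the source reports. "The series", "measured", "known", "first", "only" and "open" are said of these compounds alone.

For the measured compounds named here, compound 3 `c1cc([C@H]2CC[C@]3(CC2)OOC2(O3)C3CC4CC(C3)CC2C4)ccc1OC1CCNCC1` is the only compound of the three measured that gives an actual number in an ADME assay on microsomes from liver (Homo sapiens) for metabolic stability, read by LC-MS, tested at 1 uM; on this read-out higher numbers stand for fast clearance and lower numbers for slow clearance: compound 3 gives 15 mL.min-1.g-1. Compound 1 `c1cc([C@H]2CC[C@]3(CC2)OOC2(O3)C3CC4CC(C3)CC2C4)ccc1OCC1CCNCC1` stops at a limit of the assay, < 7 mL.min-1.g-1. Compound 2 `NCCCCCOc1ccc([C@H]2CC[C@]3(CC2)OOC2(O3)C3CC4CC(C3)CC2C4)cc1` likewise stops at a limit, < 7 mL.min-1.g-1. Both steps onto compound 3 run the same way: an at least 2.1-fold higher number from compound 1 to compound 3 (0.33 log units; beyond the scatter) and an at least 2.1-fold higher number from compound 2 to compound 3 (0.33 log units; beyond the scatter); in each, the piperidin-4-yl bound directly to the oxygen gave the higher number. The unmeasured compound 4 `c1cc([C@H]2CC[C@]3(CC2)OOC2(O3)C3CC4CC(C3)CC2C4)ccc1OCCOC1CCNCC1` carries the change (2-((piperidin-4-yl)oxy)ethyl in place of piperidin-4-yl on an oxygen on an aromatic ring). Going by the values given here, no measured step repeats that change exactly, but a flexible spacer again separates the piperidine from the oxygen, as in compound 1. Compound 4 is therefore expected to fall, a 2.1-fold lower number from compound 3 to compound 4 (0.33 log units; beyond the scatter). The estimate for compound 4 is 7 mL.min-1.g-1, within 3 mL.min-1.g-1 to 14 mL.min-1.g-1.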

Compound 4, intrinsic clearance in microsomes: < 7 mL.min-1.g-1
Compound 4 was reported as a limit; the forecaster's own chance of this, stated with the estimate: 45%; the middle value lies on the limit itself.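

In this assay, the longer group on the oxygen gives an at least 2.1-fold lower number from compound 3 to compound 4 (0.33 log units; beyond the scatter). A spacer holding an extra oxygen thus goes with the lower number just as the all-carbon spacers of compounds 1 and 2 do, and among these four compounds only the piperidin-4-yl bound directly to the oxygen reaches a number. The value of compound 4 is a limit, and the steps among compounds 1, 2 and 4 cannot be read, because all three stop at the same point: the limit of < 7 mL.min-1.g-1 in this assay, at which 3 of the 4 values shown sit.

Still open, as far as these compounds go, is whether a 1-methylpiperidin-4-yl or a cyclohexyl on that oxygen would give a number like that of compound 3.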